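Swapping the acyl cap: compound 1 to compound 3

The source may report more compounds than this note shows. Statements on the series, on what has been measured and on what is new or still open speak of the compounds shown alone.

Of the compounds shown here, two have been measured in an assay on THP-1 cells for displacement of a labelled ligand from C-C chemokine receptor type 1 (Homo sapiens); on this read-out higher numbers stand for weaker inhibition and lower numbers for stronger inhibition. Compound 1 `CC(C)[C@@H](NC(=O)c1cc2ccccc2s1)C(=O)N1CCC(c2ccc(Cl)cc2)CC1` gives 58 nM in this assay, the highest of the two numbers. Compound 2 `CC[C@@H](C)[C@@H](NC(=O)CC(C)C)C(=O)N1CCC(c2ccc(Cl)cc2)CC1` gives 34 nM in this assay; the gap between compound 2 and compound 1 is within the scatter, so the two values cannot be ordered. Compound 2 shows that an acyl group without an aromatic ring on the amide-type nitrogen gives a number in the same band as the aromatic acyl group of compound 1.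

Compound 3 `CC(C)[C@@H](NC(=O)C1CCCC1)C(=O)N1CCC(c2ccc(Cl)cc2)CC1` is not yet measured. Its difference from compound 1 is cyclopentyl in place of 1-benzothiophen-2-yl on a carbonyl carbon. For the measured compounds named here, no step between measured compounds covers this change, so its size rests on expectation only. Because compound 2 reaches 34 nM with a non-aromatic acyl group, a step of no more than the scatter, in either direction, is expected from compound 1 to compound 3: a 1.2-fold lower number from compound 1 to compound 3 (0.06 log units; within the scatter). Compound 3 is accordingly expected to give 50 nM in this assay, within a range of 20 nM to 150 nM.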

Compound 3, half-maximal inhibitory concentration: 70 nM
Estimate against measurement, compound 3: 1.4-fold (0.15 log units) below, and the stated range covers the measured number.
By their numbers in this assay, from the lowest: compounds 2, 1 and 3 (each within the scatter of the next, the first and the last beyond it).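

On the shared core, the acyl position reads a 1.2-fold higher number from compound 1 to compound 3 (0.08 log units; within the scatter) in this assay for cyclopentyl in place of 1-benzothiophen-2-yl on a carbonyl carbon. For the compounds shown here, this is the first one-place reading of this position: the aromatic pair of rings, with its sulfur and its hydrogen-bond acceptor, gives way to a non-aromatic all-carbon ring of 5 heavy atoms instead of 9, and the number stays within the scatter. For this pair, then, neither an aromatic ring nor a hetero atom in the acyl group is needed to hold the value in the same band, though a single step cannot define a trend for the position. No measurement on hand says why the two acyl groups read alike.

Still open, as far as these compounds go, is whether the same band holds for acyl groups carrying an amine, a carboxylic acid or a longer alkyl chain, and whether a plain phenyl on the carbonyl carbon reads like either group here. Also unsettled is whether this step carries over to a core other than that of compound 1.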